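Taking one methyl off compound 3

A few compounds are considered here, and "the series" means these few. Any claim that something is new, unique, unknown or untested is made for them only; others in the source may bear on it.

Of the compounds shown here, three have been measured in a functional assay on PC-3 cells (Homo sapiens); on this read-out higher numbers stand for weaker inhibition of growth and lower numbers for stronger inhibition of growth. Compound 1 (`Cc1cc(C)c2c(O)cc(-c3ccc(Cl)cc3)nc2n1`) gives 6310 nM, compound 2 (`COc1cccc(-c2cc(=O)c3ccc(C)nc3[nH]2)c1`) gives 33.1 nM and compound 3 (`COc1cccc(-c2cc(O)c3c(C)cc(C)nc3n2)c1`) gives 309 nM. Compound 3 therefore stands second highest of the three, with clear gaps beyond the scatter on both sides: its number lies above that of compound 2 and below that of compound 1.

Compound 4 (`COc1cccc(-c2cc(O)c3c(C)ccnc3n2)c1`) differs from compound 3 in one place: hydrogen in place of methyl on an aromatic carbon, next to the ring nitrogen. Among the compounds with values here, no measured pair isolates this change, so any forecast rests on thin evidence. Compound 2, at 33.1 nM, shows that numbers well under that of compound 3 occur among these close relatives. A modest move toward stronger inhibition of growth in this assay is therefore expected, although a step within the scatter remains possible. The expected change is a 2.6-fold lower number from compound 3 to compound 4 (0.41 log units; beyond the scatter). For compound 4 the estimated value is 120 nM, with an expected range of 30 nM to 450 nM.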

Compound 4, concentration for 50% growth inhibition: 26.3 nM
Beside the measured number, compound 4's estimate is 4.6-fold (0.66 log units) above it; the measured number lies below the stated range.
By their numbers in this assay, from the lowest: compounds 4 and 2 (each within the scatter of the next); then compound 3; then compound 1.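

In this assay, within the data shown here, this pair isolates a single change for the first time: hydrogen in place of methyl on an aromatic carbon, next to the ring nitrogen, gives a 12-fold lower number from compound 3 to compound 4 (1.07 log units; beyond the scatter). The earlier compounds shown here differed in more than one place and could not tie any difference in growth inhibition to this position, whereas here one methyl group alone separates the two numbers, and the step is large. Nothing at hand accounts for the size of this step.

The compounds shown leave open whether a different group at this carbon, such as an amine, a fluorine or an ethyl chain, would give a number closer to that of compound 3 or to that of compound 4. They also leave open whether the same change would give a step of this size in compound 1.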